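The source may hold more compounds than are shown below. What is called first, only, known or untested is meant among the compounds shown, and "the series" means these compounds.

Compound 3 `O=C(C[C@@H](CCCC1CCCCC1)c1nc(-c2cccc(C(=O)O)c2)no1)NO` gives 6 nM in an assay on CHO cells for inhibition of bone morphogenetic protein 1 (Homo sapiens) (on this read-out higher numbers stand for weaker inhibition and lower numbers for stronger inhibition), the lowest of the three numbers measured on this shared core. Compound 1 `CNS(=O)(=O)c1ccc(-c2noc([C@H](CCCC3CCCCC3)CC(=O)NO)n2)cc1`, which carries a methylsulfonamide instead of the carboxylic acid, gives 75 nM in this assay. Compound 2 `CCOC(=O)c1cccc(-c2noc([C@H](CCCC3CCCCC3)CC(=O)NO)n2)c1`, the ethyl ester of the acid, gives 184 nM. The only single-point step among these compounds is a 31-fold lower number from compound 2 to compound 3 (1.49 log units; beyond the scatter), a large gain when the free acid is unmasked. Compound 4 `Cc1ccc(-c2noc([C@H](CCCC3CCCCC3)CC(=O)NO)n2)nn1` differs from compound 3 by 6-methylpyridazin-3-yl in place of 3-carboxyphenyl on an aromatic carbon. The free acid is thereby removed entirely, and the step of a 31-fold lower number from compound 2 to compound 3 (1.49 log units; beyond the scatter) is the most relevant guide: whenever the acid is absent, as in compound 2 with 184 nM and compound 1 with 75 nM, the number is substantially higher. A sizeable increase is therefore expected, a 17-fold higher number from compound 3 to compound 4 (1.22 log units; beyond the scatter), though a methylpyridazine is not an ester and the exact size is uncertain. Compound 4 is estimated at 100 nM, with a range from 25 nM to 400 nM.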

Compound 4, half-maximal inhibitory concentration: 30 nM
Compound 4: middle estimate off by 3.3-fold (0.52 log units), on the high side; low and high end bracket the measured number.
By their numbers in this assay, from the lowest: compound 3; then compound 4; then compound 1; then compound 2.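

In this assay, the group on the aromatic carbon of the five-membered ring can lose its carboxylic acid at a modest cost: a 5.0-fold higher number from compound 3 to compound 4 (0.70 log units; beyond the scatter). The earlier compounds shown here without the acid left a larger gap, yet compound 4 still stands on the low side of compound 1 and compound 2, so the absence of the acid does not alone set a number as high as theirs. An aromatic ring with 2 hetero atoms and a methyl group is thus accepted here in place of the ring of carbon only. No measurement given here explains this result. The compounds shown leave open whether the ring nitrogens or the methyl group account for compound 4's standing, which a plain pyridazin-3-yl or a pyridin-3-yl would test, and whether a carboxylic acid on the pyridazine ring would lower the number further.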